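Methoxy in Place of Chloro: What to Expect for Compound 4

The compounds below may be only part of what the source reports. "The series", "measured", "known", "first", "only" and "open" are said of these compounds alone.

Three compounds have been measured in a functional assay on RPMI18226 cells (Homo sapiens) for antiproliferative activity, read by sulforhodamine B assay, with a stated time of 48 h, tested at 10 uM; on this read-out lower numbers stand for less inhibition and higher numbers for more inhibition at the one concentration tested (going by the name of the read-out):

compound 1 `Cc1ccc(NC(=O)c2c(-c3ccc(Cl)cc3)cc(-c3ccccc3)nc2N2CCCCC2)cc1`, compound 1 gives 24%
compound 2 `Cc1ccc(NC(=O)c2c(-c3ccc(Cl)cc3)cc(-c3ccccc3)nc2N)cc1`, compound 2 gives 71%
compound 3 `Cc1ccc(NC(=O)c2c(-c3ccc(Cl)cc3)cc(-c3ccccc3)nc2Nc2ccc(Cl)cc2)cc1`, compound 3 gives 58%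

Compound 3 stands second highest of the three numbers in this assay; compound 2 lies nearest, a number 13 percentage points lower from compound 2 to compound 3 (beyond the scatter), and compound 1 lies furthest, a number 34 percentage points higher from compound 1 to compound 3 (beyond the scatter). Compound 4 `COc1ccc(Nc2nc(-c3ccccc3)cc(-c3ccc(Cl)cc3)c2C(=O)Nc2ccc(C)cc2)cc1` differs from compound 3 by methoxy in place of chloro on an aromatic carbon. Among the measured compounds shown here, none of the measured steps changes a group on that phenyl ring: a number 47 percentage points higher from compound 1 to compound 2 (beyond the scatter) and a number 34 percentage points higher from compound 1 to compound 3 (beyond the scatter) replace the piperidin-1-yl, and a number 13 percentage points lower from compound 2 to compound 3 (beyond the scatter) adds the whole 4-chlorophenyl to the nitrogen. Compound 4 keeps the aryl on the nitrogen and only alters one group on it, so the step expected in this assay is small, with no clear direction: a number 3 percentage points lower from compound 3 to compound 4 (within the scatter). Compound 4 is therefore estimated at 55%, in the range 35% to 72%.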

Compound 4, a percentage reported as inhibition, at one concentration (the size of the read-out at that concentration, not a potency): 79%
Compound 4: middle estimate off by 24 percentage points, on the low side, and the stated range ends below it.
By their numbers in this assay, from the lowest: compound 1; then compound 3; then compounds 2 and 4 (each within the scatter of the next).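

In this assay, among the compounds shown here, the first change on this phenyl ring shows that the group para to a large group matters: methoxy in place of chloro gives a number 21 percentage points higher from compound 3 to compound 4 (beyond the scatter). The aryl on the nitrogen therefore need not cost inhibition, since 4-chlorophenyl gave a number 13 percentage points lower from compound 2 to compound 3 (beyond the scatter), whereas 4-methoxyphenyl gives a number 8 percentage points higher from compound 2 to compound 4 (within the scatter), and the (4-methoxyphenyl)amino group still gives a number 55 percentage points higher from compound 1 to compound 4 (beyond the scatter) against piperidin-1-yl. No evidence is at hand to explain the step from chloro to methoxy.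

The compounds shown leave open whether a hydroxyl, a dimethylamino group or a fluoro in that same place would fall with the methoxy or with the chloro. They also leave open whether an ethoxy group would keep the level seen with methoxy.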